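A few compounds are considered here, and "the series" means these few. Any claim that something is new, unique, unknown or untested is made for them only; others in the source may bear on it.

Working notes on the series. The shared core is that of compound 1 `CS(=O)(=O)c1ccc(-c2nc3ccccn3c2Sc2ccccc2)cc1`. In a functional assay on DU-145 cells (Homo sapiens) for inhibition, read by MTT assay, with a stated time of 48 h (on this read-out higher numbers stand for weaker inhibition and lower numbers for stronger inhibition), compound 1 gives 67800 nM. Compound 2 `Cc1ccc(-c2nc3ccccn3c2Sc2ccccc2)cc1` carries methyl in place of methylsulfonyl on an aromatic carbon and in this assay compound 2 gives 83300 nM; compound 3 `COc1ccc(-c2nc3ccccn3c2Sc2ccccc2)cc1` carries methoxy there and compound 3 gives 76800 nM. The three numbers sit together: a 1.2-fold higher number from compound 1 to compound 2 (0.09 log units; within the scatter), a 1.1-fold higher number from compound 1 to compound 3 (0.05 log units; within the scatter) and a 1.1-fold lower number from compound 2 to compound 3 (0.04 log units; within the scatter) all stay within the scatter, so nothing separates the three.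

Compound 4 `CS(=O)(=O)c1ccc(-c2nc3ccccn3c2Sc2cccc3ccccc23)cc1` differs from compound 1 by naphthalen-1-yl in place of phenyl on a sulfur. Going by the values given here, none of the measured steps touches the group on the sulfur; all three vary the group on the aromatic carbon, and those gave no movement. Among the compounds with values here, no measured step therefore bears directly on the change to compound 4. As far as these compounds go, with nothing to point either way, compound 4 is expected to stay near compound 1, the estimated step being a 1.2-fold lower number from compound 1 to compound 4 (0.09 log units; within the scatter), with a wide range because the change is untested here. The estimate for compound 4 in this assay is 55000 nM, between 15000 nM and 150000 nM.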

Compound 4, half-maximal inhibitory concentration: 20800 nM
The estimate for compound 4 lay 2.6-fold (0.42 log units) above the measured number; the measured number falls inside the stated range.
By their numbers in this assay, from the lowest: compound 4; then compounds 1, 3 and 2 (each within the scatter of the next).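

Going by these compounds alone, the group on the sulfur is the first place where the number moves beyond the scatter in this assay: a 3.3-fold lower number from compound 1 to compound 4 (0.51 log units; beyond the scatter), whereas all three steps on the aromatic carbon stayed within it. This single pair shows that the read-out can respond to a change at this position, here one that adds a second six-membered aromatic ring of carbon only and no hydrogen-bond donors or acceptors. Nothing available accounts for the step.

Whether the step is particular to naphthalen-1-yl remains open, as the compounds shown do not reveal how a benzyl group, a longer alkyl chain or a phenyl ring bearing an amine would behave on the sulfur. As far as these compounds go, it is also open whether methyl or methoxy on the aromatic carbon would still leave the number unmoved alongside naphthalen-1-yl.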